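A few compounds are considered here, and "the series" means these few. Any claim that something is new, unique, unknown or untested is made for them only; others in the source may bear on it.

Three compounds built on one shared core were tested in an ADME assay on HepG2 cells (Homo sapiens) for cytotoxicity, read by CellTiter-Glo and resazurin assay, with a stated time of 72 h; on this read-out lower numbers stand for an effect already at smaller amounts and higher numbers for an effect only at larger amounts of compound. Compound 1 `CC(C)N(Cc1cccc(OCCCCCC(=O)O)c1)C(=O)c1ccc(-c2cccc(N(C)C)c2)cc1` gives only a limit of the assay, > 26000 nM. Compound 2 `CCOC(=O)CCCCCOc1cccc(CN(C(=O)c2ccc(-c3cnc(OC)nc3OC)cc2)C(C)C)c1` likewise gives only a limit, > 26000 nM. Compound 3 `CCOC(=O)CCCCCOc1cccc(CN(C(=O)c2ccc(-c3cccc(OCc4ccccc4)c3)cc2)C(C)C)c1` also returns a limit rather than a number, > 26000 nM. Compound 2 therefore stands exactly where the other two stand, since all three values sit at the limit of > 26000 nM in this assay, at which 3 of the 3 values shown sit, and no true number exists for any of them.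

Compound 4 `CCOC(=O)CCCCCOc1cccc(CN(C(=O)c2ccc(-c3ccc4c(c3)OCCO4)cc2)C(C)C)c1` has not yet been measured in this assay. It differs from compound 2 in a single place: 2,3-dihydro-1,4-benzodioxin-6-yl in place of 2,4-dimethoxypyrimidin-5-yl on an aromatic carbon. Within the data shown here, no pair of measured compounds that differ in one place is available, so the size of this change cannot be read from the data. Because the measured values all sit at the limit of > 26000 nM in this assay, at which 3 of the 3 values shown sit, compound 4 is expected to give an effect in this assay only at large amounts, if at all, with a step from compound 2 of a step that the limit leaves unreadable from compound 2 to compound 4, meaning none beyond the scatter. The estimate for compound 4 is 30000 nM, within a range from 15000 nM to 60000 nM.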

Compound 4, half-maximal effective concentration: > 24400 nM
Compound 4: a limit, no number; the forecaster's own chance of this, stated with the estimate: 85%; the middle value is on the limit's open side.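

In this assay, compound 2 and compound 4 each give only a limit, so the step between them, 2,3-dihydro-1,4-benzodioxin-6-yl for 2,4-dimethoxypyrimidin-5-yl, cannot be read. The compounds shown leave open at what concentration, if any, any of them would harm these cells.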